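The source may hold more compounds than are shown below. What is called first, only, known or untested is meant among the compounds shown, and "the series" means these compounds.

Compound 1 `O=[N+]([O-])c1ccc(CN2CCC(n3cc(CC(OCc4cc(-c5ccc(Br)cc5)no4)c4ccc(Br)cc4)nn3)CC2)cc1` was examined in an ADME assay on cells (Fibroblast, Homo sapiens) for cytotoxicity, with a stated time of 48 h; a lower number here means a stronger inhibitor, a higher number a weaker inhibitor. Compound 1 gives > 25000 nM, which is a limit of the assay rather than a number. Compound 2 `O=[N+]([O-])c1ccc(CN2CCC(n3cc(CC(OCc4cc(-c5ccc(F)cc5)no4)c4ccc(Br)cc4)nn3)CC2)cc1` gives > 25000 nM, also a limit. Compound 3 `N#Cc1cccc(-c2cc(COC(Cc3cn(C4CCN(Cc5ccc([N+](=O)[O-])cc5)CC4)nn3)c3ccc(Br)cc3)on2)c1` gives > 25000 nM, again a limit. Accordingly the step that the two limits leave unreadable from compound 1 to compound 2, the step that the two limits leave unreadable from compound 1 to compound 3 and the step that the two limits leave unreadable from compound 2 to compound 3 cannot be read, because of the limit of > 25000 nM in this assay, at which 3 of the 3 values shown sit. Compound 4 `O=[N+]([O-])c1ccc(CN2CCC(n3cc(CC(OCc4cc(-c5ccccc5Br)no4)c4ccc(Br)cc4)nn3)CC2)cc1` differs from compound 1 by 2-bromophenyl in place of 4-bromophenyl on an aromatic carbon. Among the compounds with values here, no measured step bears readably on this change, so in this assay compound 4 is expected to sit near 30000 nM, within 10000 nM to 100000 nM. The resulting step is thus estimated as a step that the limit leaves unreadable from compound 1 to compound 4, with a limit rather than a number the most likely report.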

Compound 4, half-maximal inhibitory concentration: > 25000 nM
Compound 4: only a limit was reported (the forecaster's own chance of this, stated with the estimate: 85%); the middle value lies beyond the limit too.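

In this assay compound 4 gives > 25000 nM, again a limit. Its steps from compound 1, compound 2 and compound 3 therefore cannot be read, because of this: the limit of > 25000 nM in this assay, at which 4 of the 4 values shown sit. The compounds shown leave open whether the 2-bromophenyl, 4-bromophenyl, 4-fluorophenyl and 3-cyanophenyl groups differ at all in this assay.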